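Swapping methyl for isopropyl on compound 3

This account rests on a few compounds, and the source may have more. Where it says the series, first, only, none or still open, it means among the compounds named here.

In an ADME assay on H1-HeLa cells (Homo sapiens) for cytotoxicity, read by MTT assay, with a stated time of 3 days (a higher number here means that more compound is tolerated, a lower number that less compound is tolerated), compound 3 `CNC(=O)c1cc(Oc2ccc3c(C)c(C(=O)OC)sc3c2)ccn1` gives 10800 nM, the lowest of three numbers. Compound 1 `CCOC(=O)c1sc2cc(Oc3ccnc(C(=O)NC)c3)ccc2c1C` gives 50900 nM, and compound 2 `CNC(=O)c1cc(Oc2ccc3cc(C(=O)OC(C)C)sc3c2)ccn1` gives 45700 nM. Compound 4 `CNC(=O)c1cc(Oc2ccc3c(C)c(C(=O)OC(C)C)sc3c2)ccn1` has not been measured. Its structure differs by isopropyl in place of methyl on an oxygen next to a carbonyl group. Going by the values given here, the one measured step that alters only the group on that oxygen is a 4.7-fold lower number from compound 1 to compound 3 (0.67 log units; beyond the scatter), and there the smaller group gave the lower number. Compound 2 also carries isopropoxycarbonyl, with 45700 nM, though it differs elsewhere. A rise beyond the scatter is therefore expected, and the expected step is a 4.2-fold higher number from compound 3 to compound 4 (0.62 log units; beyond the scatter). Compound 4 is estimated at 45000 nM, within an expected range of 20000 nM to 90000 nM.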

Compound 4, half-maximal cytotoxic concentration: 18100 nM
Estimate against measurement, compound 4: 2.5-fold (0.40 log units) above, outside the stated range (below it).
By their numbers in this assay, from the lowest: compounds 3 and 4 (each within the scatter of the next); then compounds 2 and 1 (each within the scatter of the next).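

Isopropyl in place of methyl on that oxygen gives a 1.7-fold higher number from compound 3 to compound 4 (0.22 log units; within the scatter) and so, on its own, leaves the two compounds within the scatter. Ethyl on the same oxygen stands apart, with a 2.8-fold lower number from compound 1 to compound 4 (0.45 log units; beyond the scatter) showing that the number does not follow group size across methyl, ethyl and isopropyl. The methyl on the aromatic carbon now has its own step, a 2.5-fold lower number from compound 2 to compound 4 (0.40 log units; beyond the scatter) with isopropoxycarbonyl kept in place. Going by these compounds, how a longer chain such as butyl on that oxygen, or a carboxylic acid in place of the whole group, would read remains open. Nothing measured here explains these steps.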